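Swapping a cyclopropyl ring for cyclobutyl on a weak binder

This account rests on a few compounds, and the source may have more. Where it says the series, first, only, none or still open, it means among the compounds named here.

Among the measured compounds shown here, compound 1 `c1ccc(Cn2nnc3c(NC4CC4)nc(-c4ccccc4)nc32)cc1` is one of two compounds measured in an assay on isolated protein for binding affinity to adenosine receptor A1 (Bos taurus); on this read-out higher numbers stand for weaker inhibition and lower numbers for stronger inhibition. In this assay compound 1 gives 11000000 nM. For the measured compounds named here, its only measured companion is compound 2 `FC(F)(F)c1ccccc1Cn1nnc2c(NC3CC3)nc(-c3ccccc3)nc21`, which in this assay gives 7800000 nM. The step of a 1.4-fold lower number from compound 1 to compound 2 (0.15 log units; within the scatter) is within the scatter, so the two numbers cannot be told apart, and both point to very weak binding.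

The unmeasured compound 3 `c1ccc(Cn2nnc3c(NC4CCC4)nc(-c4ccccc4)nc32)cc1` differs from compound 1 by cyclobutyl in place of cyclopropyl on a nitrogen on an aromatic ring. Going by the values given here, no measured step concerns this part of the molecule: the only known step, a 1.4-fold lower number from compound 1 to compound 2 (0.15 log units; within the scatter), touches an aromatic carbon on a different ring and was itself within the scatter. There is therefore no basis for expecting a step beyond the scatter in this assay, in either direction, and the small change in ring size is expected to leave the number close to that of compound 1.

Compound 3 is accordingly estimated at 9000000 nM in this assay, with a range from 3000000 nM to 30000000 nM. This estimate corresponds to a step of a 1.2-fold lower number from compound 1 to compound 3 (0.09 log units; within the scatter).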

Compound 3, inhibition constant: 5000000 nM
For compound 3 the middle estimate is 1.8-fold (0.26 log units) above the measured one; low and high end bracket the measured number.
By their numbers in this assay, from the lowest: compounds 3, 2 and 1 (each within the scatter of the next, the first and the last beyond it).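

In this assay, among the compounds shown here, the step of a 2.2-fold lower number from compound 1 to compound 3 (0.34 log units; beyond the scatter) is the first in this small set to clear the scatter, so a change of the group on this nitrogen can register in the read-out. The step is only modest, however: moving from a three-membered to a four-membered carbon ring shifts the number a little, and compound 3, at 5000000 nM, is still a very weak binder. Nothing available here explains the shift.

A larger ring such as cyclopentyl could show whether the number keeps falling as the ring grows, while an open chain such as isopropyl or a plain amino group in place of cyclobutylamino could show whether a ring is needed here at all. From the compounds shown here alone, it also remains open whether cyclobutyl and the trifluoromethyl group of compound 2 would together give a number different from either change alone, or whether such small changes can ever bring this series out of the range of very weak binding.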